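Swapping the sulfonyl aryl group: compound 2 to compound 3

This account rests on a few compounds, and the source may have more. Where it says the series, first, only, none or still open, it means among the compounds named here.

Compound 2 `CC1CCN(C2CCN(S(=O)(=O)c3cccnc3F)CC2)CC1` sits at a limit in a functional assay on DLD-1 cells (Homo sapiens) for antiproliferative activity, read by CellTiter-Glo, with a stated time of 72 h; a lower number here means a stronger inhibitor, a higher number a weaker inhibitor: compound 2 gives > 5000 nM. Compound 1 `CC1CCN(C2CCN(S(=O)(=O)c3cccnc3Cl)CC2)CC1` also sits at a limit; in this assay compound 1 gives > 5000 nM. The step that the two limits leave unreadable from compound 1 to compound 2 is therefore unreadable, and the limit of > 5000 nM in this assay, at which 2 of the 2 values shown sit, is all the evidence the pair offers. Compound 3 `CC1CCN(C2CCN(S(=O)(=O)c3ccc(Br)c(Cl)c3)CC2)CC1` carries 4-bromo-3-chlorophenyl in place of 2-fluoropyridin-3-yl on a sulfonyl sulfur. Among the compounds with values here, no measured step bears on this exchange, and the single recorded step cannot be read. Compound 3 is therefore expected to remain near the same limit, with a step that the limit leaves unreadable from compound 2 to compound 3 that is not expected to exceed the scatter. Compound 3 is estimated at 8000 nM, between 3000 nM and 30000 nM.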

Compound 3, half-maximal inhibitory concentration: 12 nM
Compound 3: middle estimate off by 670-fold (2.82 log units), on the high side; measured number outside the range, below it.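

In this assay, the group on the sulfonyl sulfur now gives a readable effect: 4-bromo-3-chlorophenyl gives an at least 410-fold lower number from compound 2 to compound 3 (2.61 log units; beyond the scatter) and likewise an at least 410-fold lower number from compound 1 to compound 3 (2.61 log units; beyond the scatter). The two pyridine compounds alone gave only limits and no readable step: the limit of > 5000 nM in this assay, at which 2 of the 3 values shown sit.

The exchange alters the ring and its halogens together, leaving the share of the bromine, the chlorine and the ring nitrogen unresolved. On these data alone, whether a phenyl ring with a single halogen, or with a nitrile or methoxy group in place of bromine, holds this activity also stays open.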